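A few compounds are considered here, and "the series" means these few. Any claim that something is new, unique, unknown or untested is made for them only; others in the source may bear on it.

Of the compounds shown here, three sharing one core have been tested in a functional assay on OVCAR-5 cells (Homo sapiens) for inhibition, read by sulforhodamine B assay, with a stated time of 48 h; on this read-out higher numbers stand for weaker inhibition of growth and lower numbers for stronger inhibition of growth. Compound 1 `Nc1cc(N)c2nc(-c3ccccc3)c(NCc3ccc(Cl)c(Cl)c3)nc2c1` gives 24000 nM. Compound 2 `COc1ccc(CNc2nc3cc(N)cc(N)c3nc2-c2ccccc2)cc1OC` gives 20900 nM. Compound 3 `Nc1cc(N)c2nc(-c3ccccc3)c(NCc3ccc(F)cc3)nc2c1` gives 2630 nM, the lowest of the three numbers. The move from compound 1 to compound 2 is small, a 1.1-fold lower number from compound 1 to compound 2 (0.06 log units; within the scatter), whereas swapping in the 4-fluorophenyl group brings a clearer gain: a 9.1-fold lower number from compound 1 to compound 3 (0.96 log units; beyond the scatter) and a 7.9-fold lower number from compound 2 to compound 3 (0.90 log units; beyond the scatter).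

Compound 4 `Nc1cc(N)c2nc(-c3ccccc3)c(Oc3ccc(F)cc3)nc2c1` is not yet measured. It differs from compound 3 in one place: 4-fluorophenoxy in place of (4-fluorobenzyl)amino on an aromatic carbon. For the measured compounds named here, the measured steps all exchange one aryl group for another while keeping the (4-fluorobenzyl)amino linkage intact; none of them changes that linkage itself, so no measured step bears directly on this change. Going by these compounds, the 4-fluorophenyl ring that distinguishes compound 3 is retained, which argues for staying near the value of compound 3, but the new linkage is untested, so the expected range must be wide. Compound 4 is estimated at 5000 nM, with a range from 1200 nM to 25000 nM, which corresponds to an expected step of a 1.9-fold higher number from compound 3 to compound 4 (0.28 log units; within the scatter).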

Compound 4, concentration for 50% growth inhibition: 20400 nM
Compound 4: middle estimate off by 4.1-fold (0.61 log units), on the low side, within the range that was stated.
By their numbers in this assay, from the lowest: compound 3; then compounds 4, 2 and 1 (each within the scatter of the next).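

For the compounds shown here, this step is the first to touch the linkage itself, since the earlier steps only exchanged the aryl group at the end of an unchanged amino linkage. In this assay putting 4-fluorophenoxy in place of (4-fluorobenzyl)amino on the aromatic carbon gives a 7.8-fold higher number from compound 3 to compound 4 (0.89 log units; beyond the scatter) and so shows that keeping the 4-fluorophenyl ring is not enough to hold the lower number of compound 3: what joins that ring to the shared core matters as well. The change removes the nitrogen with its hydrogen-bond donor and the chain carbon in a single move, and nothing available here explains the rise or assigns it to either part.

The compounds shown leave open which part of the linkage counts: a 4-fluorobenzyloxy group would keep the chain carbon and exchange only nitrogen for oxygen, whereas a 4-fluoroanilino group would keep the nitrogen and lose the chain carbon. Also open, going by these compounds, is how much the fluorine contributes with the amino linkage in place, which a plain benzylamino or a 4-chlorobenzylamino group would test.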